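Closing the ring: from compound 3 to compound 4

The compounds below may be only part of what the source reports. "The series", "measured", "known", "first", "only" and "open" are said of these compounds alone.

Values in a functional assay on A549 cells (Homo sapiens) for antiproliferative activity; a lower number here means a stronger inhibitor of growth, a higher number a weaker inhibitor of growth:
- compound 1 `CC/C=C\[C@H](C)[C@H](OC(N)=O)[C@@H](C)[C@H](O)[C@@H](C)C/C(C)=C\[C@H](C)[C@@H](O)[C@@H](C)/C=C\[C@@H](O)C[C@H](O)[C@H](C)CO`: 3000 nM
- compound 2 `CC/C=C\[C@H](C)[C@H](OC(N)=O)[C@@H](C)[C@H](O)[C@@H](C)C/C(C)=C\[C@H](C)[C@@H](O)[C@@H](C)/C=C\[C@@H](O)C[C@@H]1OC(=O)[C@H](C)C[C@H]1C`: 11 nM
- compound 3 `CC/C=C\[C@H](C)[C@H](OC(N)=O)[C@@H](C)[C@H](O)[C@@H](C)C/C(C)=C\[C@H](C)[C@@H](O)[C@@H](C)/C=C\[C@@H](O)C[C@H](O)[C@H](C)C[C@H](C)C(=O)OC`: 4000 nM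

Compound 3 stands at the high end of the numbers in this assay, level with compound 1 within the scatter: a 1.3-fold higher number from compound 1 to compound 3 (0.12 log units; within the scatter). Going by the values given here, it lies far from the one ring-bearing measured compound: a 360-fold higher number from compound 2 to compound 3 (2.56 log units; beyond the scatter).

The next compound is compound 4 `CC/C=C\[C@H](C)[C@H](OC(N)=O)[C@@H](C)[C@H](O)[C@@H](C)C/C(C)=C\[C@H](C)[C@@H](O)[C@@H](C)/C=C\[C@@H](O)C[C@@H]1OC(=O)[C@H](C)[C@@H](OC)[C@H]1C`. Its change is a group of 11 heavy atoms (8 carbon, 3 oxygen; one six-membered non-aromatic ring with 1 hetero atom) in place of a group of 11 heavy atoms (8 carbon, 3 oxygen; no ring), on a saturated chain carbon, two bonds along the chain from a double-bonded chain carbon and an oxygen on a saturated carbon: the open group gives way to a group with one six-membered non-aromatic ring with 1 hetero atom.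

Among the compounds with values here, the steps that bear on this are the two large ones into and out of compound 2: a 270-fold lower number from compound 1 to compound 2 (2.44 log units; beyond the scatter) and a 360-fold higher number from compound 2 to compound 3 (2.56 log units; beyond the scatter). Compound 4 also carries such a ring, so a large step to a lower number is expected. Within the data shown here, its ring group is not the same as that of compound 2, and no measured compound shows what that difference does, so the expected step is set somewhat smaller. The estimated step is a 130-fold lower number from compound 3 to compound 4 (2.12 log units; beyond the scatter). For compound 4 the expected value is 30 nM, with an estimated range of 8 nM to 150 nM.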

Compound 4, concentration for 50% growth inhibition: 6.5 nM
Compound 4: the middle estimate sits 4.6-fold (0.66 log units) above what was measured; the measured number lies below the stated range.
By their numbers in this assay, from the lowest: compounds 4 and 2 (each within the scatter of the next); then compounds 1 and 3 (each within the scatter of the next).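

In this assay, the large gain from ring closure at this position now appears with a second ring group: a 620-fold lower number from compound 3 to compound 4 (2.79 log units; beyond the scatter), and a 460-fold lower number from compound 1 to compound 4 (2.66 log units; beyond the scatter). For the step from compound 3, the leaving and entering groups have the same heavy-atom composition, so the large step does not come with any change in that composition. Going by these compounds alone, the first change on the ring itself, methoxy in place of hydrogen on a saturated ring carbon, stays within the scatter: a 1.7-fold lower number from compound 2 to compound 4 (0.23 log units; within the scatter).

Going by these compounds, whether an amine or a longer chain such as butoxy on that ring carbon would also stay level with compound 2 remains open. No measurement at hand gives a reason for the large steps seen with either ring group.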